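A few compounds are considered here, and "the series" means these few. Any claim that something is new, unique, unknown or untested is made for them only; others in the source may bear on it.

Measured so far:
- compound 1, `O/N=C(/CCN1CCN(c2ncccn2)CC1)c1ccccc1`: 69 nM
- compound 2, `CO/N=C(\CCN1CCN(c2ccccc2OC(C)C)CC1)c1ccc(F)cc1`: 594 nM

In a functional assay on HEK293 cells with D(4) dopamine receptor (Homo sapiens) as the target, read by FLIPR (a higher number here means that more compound is needed for the effect, a lower number that less compound is needed), compound 1 gives 69 nM, and in this assay compound 2 gives 594 nM. Compound 2 therefore stands at the highest of the two numbers measured, with compound 1 the nearest and clearly lower, a gap well beyond the scatter of repeated measurements. Within the data shown here, no single-change pair exists among the measured compounds, so the two values can only be set side by side.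

Compound 3, `CO/N=C(/CCN1CCN(c2ccccc2OC(C)C)CC1)c1ccc(F)cc1`, is the geometric partner of compound 2: the two compounds have the same atoms and bonds and differ only in configuration as drawn: 1 of 1 stereo elements differ; a double bond is drawn E in compound 2 and Z in compound 3. Nothing in the measured pair tells how much such a change in drawn configuration shifts this assay, so the direction of the step is open. The estimate for compound 3 is 350 nM, within a range from 70 nM to 1800 nM, which means an expected step of a 1.7-fold lower number from compound 2 to compound 3 (0.23 log units; within the scatter).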

Compound 3, half-maximal effective concentration: 601 nM
For compound 3 the middle estimate is 1.7-fold (0.23 log units) below the measured one; measured number inside the range.
By their numbers in this assay, from the lowest: compound 1; then compounds 2 and 3 (each within the scatter of the next).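

Going from the E to the Z drawing of the double bond gives a 1.0-fold higher number from compound 2 to compound 3 (0.01 log units; within the scatter) in this assay, so the two forms stand level. Among these compounds, this is the first single-change pair among the measured compounds, and it shows that, with the rest of the structure held fixed, the drawn configuration of this double bond does not separate the two numbers: the fact that compounds 2 and 3 differ only in the configuration as drawn.

The compounds shown leave open whether the double bond stays as silent when the surrounding groups change, for example with a benzyl ether or a chloro substituent in the structure. They also leave open which of the several differences between compound 1 and the other two compounds accounts for its separate number, since that comparison spans more than one place.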